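The source may report more compounds than this note shows. Statements on the series, on what has been measured and on what is new or still open speak of the compounds shown alone.

The set of four compounds shares one core and varies a chain on one side of it. Compound 1 `CCC(CC)(c1ccc(OCC(=O)C(C)(C)CCCc2ccccc2)c(C)c1)c1ccc(OC[C@@H](O)CO)c(C)c1` carries a ketone on that chain, and in an assay on HL-60 cells for activation of vitamin D3 receptor (Homo sapiens) (a higher number here means that more compound is needed for the effect, a lower number that less compound is needed), compound 1 reaches only a limit of the measurement, > 30000 nM. Compound 2 `CCC(CC)(c1ccc(OCC(=O)C(C)(C)CCCCc2ccccc2)c(C)c1)c1ccc(OC[C@@H](O)CO)c(C)c1` differs from it by benzyl in place of phenyl on a saturated chain carbon, four bonds along the chain from a carbonyl carbon, and in this assay compound 2 likewise reaches only a limit, > 30000 nM. The step that the two limits leave unreadable from compound 1 to compound 2 is therefore unreadable because of the limit of > 30000 nM in this assay, at which 2 of the 3 values shown sit. Compound 3 `CCC(CC)(c1ccc(OCC(O)C(C)(C)Cc2ccccc2)c(C)c1)c1ccc(OC[C@@H](O)CO)c(C)c1` carries an alcohol instead of the ketone and a shorter chain; how its core differs from that of compound 1 is not broken down here. In this assay, among the compounds with values here, compound 3 gives 11000 nM, the only number among the three measured values. Compound 4 `CCC(CC)(c1ccc(OCC(O)C(C)(C)CCc2ccccc2)c(C)c1)c1ccc(OC[C@@H](O)CO)c(C)c1` has not yet been measured; it differs from compound 3 by benzyl in place of phenyl on a saturated chain carbon, three bonds along the chain from an oxygen on a saturated carbon. Within the data shown here, this is the same kind of change as the one from compound 1 to compound 2, but the place is not the same: there the change sat four bonds along the chain from a carbonyl carbon, here it sits three bonds along the chain from an oxygen on a saturated carbon. The earlier step offers no size to carry over. Compound 4 is therefore expected to land at about 15000 nM, within 4000 nM to 30000 nM. Among the measured compounds shown here, that expectation rests on compound 3 and its 11000 nM, the only number available. The step he expects is a 1.4-fold higher number from compound 3 to compound 4 (0.13 log units; within the scatter).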

Compound 4, half-maximal effective concentration: 7100 nM
For compound 4 the middle estimate is 2.1-fold (0.32 log units) above the measured one, within the range that was stated.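

On the alcohol chain, in this assay, putting benzyl in place of phenyl, three bonds along the chain from an oxygen on a saturated carbon, gives a 1.5-fold lower number from compound 3 to compound 4 (0.19 log units; within the scatter), so this single example shows a change of this kind that leaves the read-out within the usual scatter. The same kind of change on the ketone chain, from compound 1 to compound 2, cannot be read, because both values are limits and not numbers: the limit of > 30000 nM in this assay, at which 2 of the 4 values shown sit. The series therefore offers only one readable size for this change, so it neither shows that the result carries over from the alcohol chain to the ketone chain nor shows that it fails to do so.

The compounds shown leave open whether an alcohol carrying the longer chain of compound 1 or compound 2 would give a readable number, since compound 1 and compound 3 differ in more than one place and the ketone and the chain length cannot be separated between them. They also leave open how an amine or a carboxylic acid in place of the alcohol would behave on the same chain.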